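Amine-tailed side chains on the shared core

The compounds below may be only part of what the source reports. "The series", "measured", "known", "first", "only" and "open" are said of these compounds alone.

Values in a functional assay on MCF7 cells (Homo sapiens) for cytotoxicity, read by MTT assay, with a stated time of 72 h (on this read-out higher numbers stand for weaker inhibition and lower numbers for stronger inhibition), for the measured compounds:
compound 1 `CC1(C)O[C@@H](CO)[C@H](Cn2cc(Cn3c4c(c5ccccc53)C(=O)c3c[n+]([O-])c5ccccc5c3C4=O)nn2)O1`: 690 nM
compound 2 `O=C1c2c[n+]([O-])c3ccccc3c2C(=O)c2c1c1ccccc1n2Cc1cn(CC(O)CO)nn1`: 1110 nM
compound 3 `O=C1c2c[n+]([O-])c3ccccc3c2C(=O)c2c1c1ccccc1n2CCCCN1CCCCC1`: 150 nM

Compound 3 gives the lowest number of the three; compound 1 sits closer to it than compound 2, and both gaps lie beyond the scatter. The two measured steps are of unequal weight. The step of a 1.6-fold higher number from compound 1 to compound 2 (0.21 log units; within the scatter) stays within the scatter. The step of a 7.4-fold lower number from compound 2 to compound 3 (0.87 log units; beyond the scatter) is the only one that reaches beyond it, and it replaces the whole triazole-bearing chain with an amine-terminated chain.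

Compound 4 `CCCCN1CCN(CCCCn2c3c(c4ccccc42)C(=O)c2c[n+]([O-])c4ccccc4c2C3=O)CC1` keeps that amine-terminated chain and changes only its end: 4-butylpiperazin-1-yl in place of piperidin-1-yl on a saturated chain carbon, four bonds along the chain from an aromatic nitrogen. For the measured compounds named here, no measured step exchanges one saturated amine ring for another, so the closest precedent is the step from compound 2 to compound 3, which already brought in the amine end and is much larger in kind than the present change. The expectation is therefore a small movement in this assay, not clearly beyond the scatter, with a slight lean toward a lower number.

For compound 4 the estimated value in this assay is 120 nM, within 50 nM to 300 nM, an expected step of a 1.3-fold lower number from compound 3 to compound 4 (0.10 log units; within the scatter).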

Compound 4, half-maximal inhibitory concentration: 6900 nM
Beside the measured number, compound 4's estimate is 58-fold (1.76 log units) below it; the measured number lies above the stated range.
By their numbers in this assay, from the lowest: compound 3; then compounds 1 and 2 (each within the scatter of the next); then compound 4.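

The amine-terminated chain alone does not secure a low number: with the chain held constant, exchanging piperidin-1-yl for 4-butylpiperazin-1-yl at its end, on a saturated chain carbon, four bonds along the chain from an aromatic nitrogen, gives a 46-fold higher number from compound 3 to compound 4 (1.66 log units; beyond the scatter) in this assay. This single change at the chain end therefore outweighs the replacement of the whole triazole-bearing chain, a 7.4-fold lower number from compound 2 to compound 3 (0.87 log units; beyond the scatter), and the low number of compound 3 belongs, among the compounds shown, to the chain ending in piperidin-1-yl rather than to amine-terminated chains in general. The entering group brings a second ring nitrogen and a butyl group together, and no available evidence accounts for the loss or assigns it to either part.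

The compounds shown do not separate those two parts: piperazin-1-yl without a substituent and 4-methylpiperazin-1-yl would show whether the ring or the length of the butyl group carries the step. Morpholin-4-yl at the same chain end, and a shorter or longer chain ending in piperidin-1-yl, would show how narrowly the number of compound 3 depends on this exact chain and end.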